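Benzimidazole-free notes: sulfur-linked chain variants of the shared core

A few compounds are considered here, and "the series" means these few. Any claim that something is new, unique, unknown or untested is made for them only; others in the source may bear on it.

Compound 2 `CCCCCCSc1nc2ccccc2n1CC(=O)O` gives 1360 nM in an assay on HEK293 cells for displacement of a labelled ligand from prostaglandin D2 receptor 2 (Homo sapiens); a lower number here means a stronger inhibitor, a higher number a weaker inhibitor. Among the three measured compounds it holds the second highest number: compound 1 `O=C(O)Cn1c(SCCCOc2ccccc2)nc2ccccc21` gives 786 nM in this assay, and compound 3 `CCOC(=O)CCCCSc1nc2ccccc2n1CC(=O)O` gives 2360 nM, both within the scatter of compound 2. The steps seen so far change the group three or four bonds along the chain from the sulfur: a 1.7-fold higher number from compound 1 to compound 2 (0.24 log units; within the scatter), a 3.0-fold higher number from compound 1 to compound 3 (0.48 log units; beyond the scatter) and a 1.7-fold higher number from compound 2 to compound 3 (0.24 log units; within the scatter).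

Compound 4 `Cc1ccc(CSc2nc3ccccc3n2CC(=O)O)cc1` differs from compound 2 by 4-methylphenyl in place of pentyl on a saturated chain carbon bound to a sulfur. Within the data shown here, no measured step touches the chain carbon bound to the sulfur, and none replaces the full chain by a ring, so only the general scale of the steps above is available; they stay within or just beyond the scatter. The expected step of a 1.5-fold lower number from compound 2 to compound 4 (0.18 log units; within the scatter) in this assay is therefore small, leaning toward a somewhat lower number in the direction of compound 1, whose 786 nM is the lowest seen. Compound 4 is estimated at 900 nM, with a range from 300 nM to 3000 nM.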

Compound 4, half-maximal inhibitory concentration: 220 nM
Beside the measured number, compound 4's estimate is 4.1-fold (0.61 log units) above it; measured number below the stated range.
By their numbers in this assay, from the lowest: compound 4; then compounds 1, 2 and 3 (each within the scatter of the next, the first and the last beyond it).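

At this position, the chain carbon bound to a sulfur, replacing pentyl with 4-methylphenyl in this assay gives a 6.2-fold lower number from compound 2 to compound 4 (0.79 log units; beyond the scatter). Among these compounds, this step is beyond the scatter and larger than the largest earlier step, a 3.0-fold higher number from compound 1 to compound 3 (0.48 log units; beyond the scatter), which lies further along the chain, so the end of the sulfur-linked chain is not the only place where a change shifts the number. Nothing available accounts for the size of this step.

Among the compounds shown here, the single change brings in the ring and its methyl together, so a plain phenyl or a 4-chlorophenyl would be needed to separate their contributions. A 2-phenylethyl group on the sulfur would show how the number responds to a longer link between the sulfur and the ring.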